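The source may hold more compounds than are shown below. What is called first, only, known or untested is meant among the compounds shown, and "the series" means these compounds.

The measured compounds are:

compound 1, `CCCCCCN(CCCCCSc1nc2ccccc2o1)C(=O)Nc1ccc(F)cc1F`, with 3500 nM in an assay on cells (Macrophage) for inhibition of sterol O-acyltransferase 1 (Mus musculus); a higher number here means a weaker inhibitor, a lower number a stronger inhibitor;
compound 2, `CCCCCCN(CCCCCSc1nc2cc(C)ccc2[nH]1)C(=O)Nc1ccc(F)cc1F`, with 2060 nM;
compound 3, `CCCCCCCN(CCCCCSc1nc(O)c2ccccc2n1)C(=O)Nc1ccc(F)cc1F`, with 11000 nM.

Compound 3 gives the highest number of the three; compound 1 and compound 2 both lie lower by gaps that are beyond the scatter, so compound 3 is the weakest inhibitor on these numbers. Compound 4, `CCCCCCCN(CCCCCSc1[nH]cnc2nncc1-2)C(=O)Nc1ccc(F)cc1F`, has not yet been measured. It differs from compound 3 by a group of 9 heavy atoms (5 carbon, 4 nitrogen; one five-membered aromatic ring with 2 hetero atoms, one six-membered aromatic ring with 2 hetero atoms) in place of a group of 11 heavy atoms (8 carbon, 2 nitrogen, 1 oxygen; one six-membered aromatic ring of carbon only, one six-membered aromatic ring with 2 hetero atoms), on a sulfur.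

For the measured compounds named here, only one measured step resembles this change: a 1.7-fold lower number from compound 1 to compound 2 (0.23 log units; within the scatter), in which one fused heteroaryl on the sulfur was exchanged for another and the number stayed within the scatter. That step does not involve the group that leaves compound 3, and compound 3 and compound 1 also differ in the chain on the nitrogen, so the comparison is loose. Going by the values given here, still, the two values show that compound 3 carries the highest number, and the group that leaves it is the one linked to that number. A fused heteroaryl swap is therefore expected to bring the number back toward the range of compound 1 and compound 2, modestly, though a step within the scatter cannot be excluded. The estimated step is a 1.8-fold lower number from compound 3 to compound 4 (0.26 log units; within the scatter), and compound 4 is expected to give about 6000 nM, between 1500 nM and 25000 nM.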

Compound 4, half-maximal inhibitory concentration in the sterol O-acyltransferase 1 assay: 3310 nM
Estimate against measurement, compound 4: 1.8-fold (0.26 log units) above, and the stated range covers the measured number.
By their numbers in the sterol O-acyltransferase 1 assay, from the lowest: compounds 2, 4 and 1 (each within the scatter of the next); then compound 3.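

With the chain on the nitrogen held constant, compound 3 and compound 4 differ only in the group on the sulfur, and replacing 4-hydroxyquinazolin-2-yl with the group of 9 heavy atoms gives, in the sterol O-acyltransferase 1 assay, a 3.3-fold lower number from compound 3 to compound 4 (0.52 log units; beyond the scatter). For the compounds shown here, the only earlier step at this position, in the sterol O-acyltransferase 1 assay, was a 1.7-fold lower number from compound 1 to compound 2 (0.23 log units; within the scatter), so this pair is the first to show that the number responds to the group on the sulfur by more than the scatter, even though both groups carry the same counts of hydrogen-bond donors and acceptors and no net charge. In a physicochemical assay for lipophilicity (a higher number here means a more lipophilic compound, a lower number a more polar compound), compound 3 gives 6.17 and compound 4 gives 5.6, so the same exchange also lowers the number, and here stronger inhibition comes with lower lipophilicity: the measured partition coefficient of compound 3, 6.17, and of compound 4, 5.6, a number 0.57 log units lower (beyond the scatter)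

A single pair cannot separate the part played by lipophilicity from that of the change in the rings themselves, so no link between the two can be claimed. Going by these compounds, it also remains open how the number would respond to an amine or a carboxylic acid on the group on the sulfur, or to an octyl chain on the nitrogen.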